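Ring Substitution Pattern and Tolerated Concentration on MT4 Cells

The compounds below may be only part of what the source reports. "The series", "measured", "known", "first", "only" and "open" are said of these compounds alone.

Compound 1 `Cc1ccccc1-c1cc(C)c(Nc2ccnc(Nc3ccc(C#N)cc3)n2)c(C)c1` gives 3820 nM in an ADME assay on MT4 cells (Homo sapiens) for cytotoxicity, read by MTT assay, with a stated time of 4 days; a lower number here means that less compound is tolerated, a higher number that more compound is tolerated.
Compound 2 `Cc1cc(C)cc(-c2cc(C)c(Nc3ccnc(Nc4ccc(C#N)cc4)n3)c(C)c2)c1` gives 4140 nM in this assay.
Compound 3 `Cc1cc(-c2cccc(F)c2)cc(C)c1Nc1ccnc(Nc2ccc(C#N)cc2)n1` gives 4120 nM in this assay.

Compound 2 has the highest of the three numbers in this assay, but its neighbours sit so close that no order can be read: the step of a 1.1-fold higher number from compound 1 to compound 2 (0.03 log units; within the scatter) and the step of a 1.0-fold lower number from compound 2 to compound 3 (0.00 log units; within the scatter) both lie within the scatter, as does a 1.1-fold higher number from compound 1 to compound 3 (0.03 log units; within the scatter). Across these three compounds the group on the aromatic carbon of the shared core has been exchanged three ways without any change that rises above measurement noise.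

Compound 4 `Cc1cc(-c2c(C)cccc2C)cc(C)c1Nc1ccnc(Nc2ccc(C#N)cc2)n1` is the next member. Its difference from compound 2 is 2,6-dimethylphenyl in place of 3,5-dimethylphenyl on an aromatic carbon. All three measured steps bear on this change, since each of them also exchanges the group on that same aromatic carbon, and none of them moved the number beyond the scatter. The account therefore expects no step beyond the scatter, in either direction, for compound 4 in this assay, which means a step of a 1.0-fold lower number from compound 2 to compound 4 (0.01 log units; within the scatter) from compound 2. The estimate for compound 4 in this assay is 4000 nM, with a range from 2000 nM to 8000 nM.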

Compound 4, half-maximal cytotoxic concentration: 2590 nM
The estimate for compound 4 lay 1.5-fold (0.19 log units) above the measured number, within the range that was stated.
By their numbers in this assay, from the lowest: compounds 4, 1, 3 and 2 (each within the scatter of the next).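

Exchanging 3,5-dimethylphenyl for 2,6-dimethylphenyl, two groups with the same atoms joined differently, gives a 1.6-fold lower number from compound 2 to compound 4 (0.20 log units; within the scatter) in this assay and so shows that, at this aromatic carbon, even this rearrangement of the two methyl groups stays inside the noise of the measurement. The comparison with the fluorinated group gives a 1.6-fold lower number from compound 3 to compound 4 (0.20 log units; within the scatter) and the placing of methyl where hydrogen stood gives a 1.5-fold lower number from compound 1 to compound 4 (0.17 log units; within the scatter) as a second reading of the same position, and this one shows that a further methyl group on the incoming ring does not separate the numbers either. These steps are larger than those among the first three compounds, yet all of them remain within the scatter, so the four compounds cannot be put in a firm order and no trend can be claimed. Nothing available here offers an explanation for the numbers.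

Every group shown at this position is a six-membered aromatic ring of carbon only, with methyl or fluorine on it, so it remains open whether an amine, a carboxylic acid or a longer alkyl chain there would take the number in this assay beyond the scatter. As far as these compounds go, the other positions of the shared core are not varied in these compounds and remain open too.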